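The compounds below may be only part of what the source reports. "The series", "measured", "known", "first", "only" and "open" are said of these compounds alone.

Compound 1 is a diterpene glycoside with the structure `C=C[C@@](C)(CC[C@H]1C(C)=CC[C@H]2C(C)(C)CCC[C@]12C)O[C@@H]1O[C@@H](C)[C@@H](OC(C)=O)[C@H](O)[C@H]1O`. In a functional assay on SK-OV-3 cells (Homo sapiens) for cytotoxicity, read by sulforhodamine B assay (on this read-out lower numbers stand for an effect already at smaller amounts and higher numbers for an effect only at larger amounts of compound), compound 1 gives 3.4 ug/mL, the only numerical result in this small set. The related compound 2, with the structure `C=C[C@](C)(O)CC[C@H]1C(=C)[C@H](O)C[C@H]2C(C)(C)CCC[C@]12C`, carries no sugar; in this assay compound 2 is recorded only as a limit, > 5 ug/mL, which says that no half-maximal effect was reached within the tested range. Compound 3, with the structure `C=C[C@@](C)(CC[C@H]1C(C)=CC[C@H]2C(C)(C)CCC[C@]12C)O[C@@H]1O[C@H](C)[C@H](OC(C)=O)[C@H](O)[C@H]1O`, is yet to be tested. It is a stereoisomer of compound 1 at the sugar: the two compounds have the same atoms and bonds and differ only in configuration as drawn: 2 of 9 stereo elements differ; a stereocentre at a saturated ring carbon is drawn S in compound 1 and R in compound 3; a stereocentre at a saturated ring carbon is drawn S in compound 1 and R in compound 3. Among the measured compounds shown here, no measured pair of compounds here differs at a single stereocentre, so the data offer no direct guide to the size of such a step. Compound 3 keeps every atom and bond of compound 1, and the expected step from compound 1 to compound 3 in this assay is a 1.2-fold higher number from compound 1 to compound 3 (0.07 log units; within the scatter), that is, none beyond the scatter. Compound 3 is therefore expected to give about 4 ug/mL, with a range of 1.7 ug/mL to 9 ug/mL, with some chance of reaching only a limit, as compound 2 did.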

Compound 3, concentration for half-maximal effect: 5.8 ug/mL
The estimate for compound 3 lay 1.5-fold (0.16 log units) below the measured number; low and high end bracket the measured number.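

In this assay, changing the configuration at two stereocentres of the sugar, with every atom and bond kept, gives a 1.7-fold higher number from compound 1 to compound 3 (0.23 log units; within the scatter). Among the compounds shown here, this is the first step in the set that can be read between two numbers, and it shows that a change of this kind at the sugar does not stand out from the usual differences between repeated measurements. The comparison isolates configuration at the sugar from all other structural features, because only one kind of difference separates the pair: the fact that compounds 1 and 3 differ only in the configuration as drawn

Going by these compounds, since both stereocentres changed together, the effect of either one alone stays open, and a larger effect from one could be offset by the other. Also open is how this assay would respond if the acetyl group on the sugar gave way to an amine or a carboxylic acid, since the compounds shown keep that part of the sugar unchanged whenever the sugar is present.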